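The source may hold more compounds than are shown below. What is called first, only, known or untested is meant among the compounds shown, and "the series" means these compounds.

For the measured compounds named here, compound 1 `CC(=O)Cn1cc(CNC(=O)c2cnc(Nc3ccc(C#N)cc3)cc2Oc2c(C)cc(C)cc2C)nn1` is the only member of this small set with a definite number in an ADME assay on MT4 cells (Homo sapiens) for cytotoxicity, read by MTT assay, with a stated time of 5 days; a lower number here means that less compound is tolerated, a higher number that more compound is tolerated: compound 1 gives 19400 nM. Going by the values given here, the one other member is compound 2 `Cc1cc(C)c(Oc2cc(Nc3ccc(C#N)cc3)ncc2C(=O)NCc2cn(Cc3ccc(F)cc3)nn2)c(C)c1`, whose value in this assay is not a number but the limit of >= 153000 nM. The step of an at least 7.8-fold higher number from compound 1 to compound 2 (0.89 log units; beyond the scatter) is therefore at least modest, and its size rests on (the limit of >= 153000 nM in this assay, at which 1 of the 2 values shown sits).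

Compound 3 `Cc1cc(C)c(Oc2cc(Nc3ccc(C#N)cc3)ncc2C(=O)NCc2cn(Cc3cccc([N+](=O)[O-])c3)nn2)c(C)c1` has not yet been measured. It differs from compound 1 by 3-nitrophenyl in place of acetyl on a saturated chain carbon bound to an aromatic nitrogen, a change that shares its place and its general character with the step from compound 1 to compound 2: again an aromatic ring on a saturated chain carbon bound to an aromatic nitrogen takes the place of acetyl. Among the compounds with values here, the only measured step that bears on compound 3 is thus an at least 7.8-fold higher number from compound 1 to compound 2 (0.89 log units; beyond the scatter), which moved the value up to the limit. Compound 3 is expected to follow that direction, so that a 6.2-fold higher number from compound 1 to compound 3 (0.79 log units; beyond the scatter) is estimated to be a rise of comparable size. In this assay compound 3 is expected to give roughly 120000 nM, in a range from 40000 nM to 200000 nM, quite possibly again as a limit.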

Compound 3, half-maximal cytotoxic concentration: >= 156000 nM
Compound 3: no number, only a limit (the forecaster's own chance of this, stated with the estimate: 55%); at least 1.3-fold (0.11 log units) between middle value and limit.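

Replacing acetyl with 3-nitrophenyl on a saturated chain carbon bound to an aromatic nitrogen gives, in this assay, an at least 8.0-fold higher number from compound 1 to compound 3 (0.90 log units; beyond the scatter), so the rise at this place is now seen with two different aromatic groups, 4-fluorophenyl and 3-nitrophenyl, and no compound shown goes against it. The value of compound 3 is a limit and not a number, and the size of this step rests on it: the limit of >= 156000 nM in this assay, at which 1 of the 3 values shown sits. Compound 2 and compound 3 both carry limits, and the step between them cannot be read, so 3-nitrophenyl and 4-fluorophenyl cannot be placed in any order in this assay.

Acetyl is the only group in this set at this place that is not an aromatic ring, which leaves open whether the rise depends on the aromatic ring or simply on acetyl being gone. On these data alone, a cyclohexyl ring or a plain propyl chain at the same place could separate those two readings, and whether an amine or a carboxylic acid on the phenyl ring would bring the number down in this assay also stays open.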